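Aryl swap on the thiazolyl hydrazone series: cytotoxicity notes

The compounds below may be only part of what the source reports. "The series", "measured", "known", "first", "only" and "open" are said of these compounds alone.

Measured so far:
compound 1 `COc1ccc(-n2cc(COc3ccc(/C=N/Nc4nc(-c5ccc(Br)cc5)cs4)cc3)nn2)cc1` — 35600 nM
compound 2 `COc1ccc(-n2cc(COc3ccc(/C=N/Nc4nc(-c5cc6cccc(OC)c6oc5=O)cs4)cc3)nn2)cc1` — 34500 nM

In an ADME assay on THP-1 cells (Homo sapiens) for cytotoxicity (on this read-out higher numbers stand for lower toxicity in this test and lower numbers for higher toxicity in this test), compound 1 gives 35600 nM, the higher of the two numbers recorded; its nearest neighbour is compound 2, which in this assay gives 34500 nM. The two values lie within the scatter of each other, so no order between them can be read. Both compounds share the same core and differ only in the aryl substituent on the thiazole, and on this evidence the read-out is insensitive to that part of the molecule. Among the measured compounds shown here, no step between compounds differing in a single place is available.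

Compound 3 `COc1ccc(-n2cc(COc3ccc(/C=N/Nc4nc(-c5ccc([N+](=O)[O-])cc5)cs4)cc3)nn2)cc1` has not yet been measured. It differs from compound 1 as nitro in place of bromo on an aromatic carbon. Given that compound 1 gives 35600 nM and compound 2 gives 34500 nM with a quite different aryl group, the expectation for this assay is a step from compound 1 to compound 3 of no size beyond the scatter, in either direction, estimated as a 1.1-fold lower number from compound 1 to compound 3 (0.03 log units; within the scatter). For compound 3 the value in this assay is expected to be about 33000 nM, with a range from 15000 nM to 70000 nM.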

Compound 3, half-maximal cytotoxic concentration: 37900 nM
The estimate for compound 3 lay 1.1-fold (0.06 log units) below the measured number, and the stated range covers the measured number.
By their numbers in this assay, from the lowest: compounds 2, 1 and 3 (each within the scatter of the next).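

In this assay, among the compounds shown here, nitro in place of bromo on an aromatic carbon gives a 1.1-fold higher number from compound 1 to compound 3 (0.03 log units; within the scatter), which is the first step where a single group differs. At this place, para to a large group, bromo with 0 hydrogen-bond acceptors can therefore give way to nitro with 2 hydrogen-bond acceptors, and no net charge on either, without a shift in this read-out beyond the scatter. Nothing available accounts for this flat result.

Bromo and nitro both carry no net charge, so it remains open whether an amine or a carboxylic acid at the same place on the 4-substituted phenyl would also leave the read-out within the scatter of compound 1. From the compounds shown here alone, it also remains open whether a longer chain at this place, or any change elsewhere on the shared core, would give a step beyond the scatter in this assay.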